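Amide nitrogen substituent swap at the pyridine carboxamide

A few compounds are considered here, and "the series" means these few. Any claim that something is new, unique, unknown or untested is made for them only; others in the source may bear on it.

Two compounds of this series have been run in a functional assay on HEK293 cells for positive allosteric modulation of metabotropic glutamate receptor 5 (Rattus norvegicus), read by fluorescence and calcium flux; a higher number here means a larger maximal response, a lower number a smaller maximal response. Compound 1 `C[C@@H](NC(=O)c1ccc(C#Cc2ccncc2)cn1)C(C)(C)O` gives 66.6%. Compound 2 `CC(C)[C@@H](C)NC(=O)c1ccc(C#Cc2cccc(F)c2)cn1` gives 69.3%. Within the data shown here, compound 2 stands at the top of these two numbers, but its only neighbour, compound 1, lies within the usual scatter of it, so no ordering between the two is claimed.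

The next compound, compound 3 `CC1(CNC(=O)c2ccc(C#Cc3cccc(F)c3)cn2)COC1`, differs from compound 2 in one place: (3-methyloxetan-3-yl)methyl in place of 1,2-dimethylpropyl on an amide-type nitrogen.

Among the measured compounds shown here, no step between measured compounds covers this kind of change, so there is no measured footing for its size or direction. The two numbers available sit close together, which argues for expecting a maximal response in the same region rather than a shift beyond the scatter. For compound 3 the expected step in this assay is a number 3.3 percentage points lower from compound 2 to compound 3 (within the scatter), that is, no change beyond the scatter. Compound 3 is estimated at 66%, with a range from 48% to 84%.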

Compound 3, largest response reached (reported as efficacy), in percent of the reference or control that the assay uses: 60.4%
For compound 3 the middle estimate is 5.6 percentage points above the measured one; the measured number falls inside the stated range.
By their numbers in this assay, from the lowest: compounds 3, 1 and 2 (each within the scatter of the next).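

In this assay the first step measured at this position reads a number 8.9 percentage points lower from compound 2 to compound 3 (within the scatter) for (3-methyloxetan-3-yl)methyl in place of 1,2-dimethylpropyl on the amide-type nitrogen. The maximal response therefore shows no change beyond the scatter when a four-membered non-aromatic ring with a hydrogen-bond acceptor enters and the defined stereocentre of the leaving group goes. No available measurement accounts for this result.

Open, on these data alone, is whether cyclobutylmethyl, the all-carbon ring counterpart, a 2-methoxyethyl chain or a carboxylic acid on this nitrogen would keep the response in the same region. Also open, as far as these compounds go, is whether the same swap reads alike on the core of compound 1, as a single step at this position gives no trend.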